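The source may report more compounds than this note shows. Statements on the series, on what has been measured and on what is new or still open speak of the compounds shown alone.

Measured in a functional assay on MCF7 cells (Homo sapiens) for antiproliferative activity, read by MTT assay, with a stated time of 72 h; on this read-out lower numbers stand for stronger inhibition and higher numbers for weaker inhibition:
- Compound 1 `O=C(N/N=C/c1ccccn1)c1cccc(S(=O)(=O)N2CCOCC2)c1`: > 100000 nM
- Compound 2 `O=C(N/N=C/c1cc(Cl)ccc1O)c1cccc(S(=O)(=O)N2CCOCC2)c1`: 16500 nM

The entry for compound 1 is a limit of the assay, > 100000 nM. Going by the values given here, compound 2 therefore holds the only actual number in this assay, 16500 nM. Among the compounds with values here, the one measured step that bears on what follows is an at least 6.0-fold lower number from compound 1 to compound 2 (0.78 log units; beyond the scatter), with 5-chloro-2-hydroxyphenyl in place of pyridin-2-yl on a carbon with a double bond to nitrogen. Compound 3 `O=C(N/N=C/c1cc(Br)cc(Br)c1O)c1cccc(S(=O)(=O)N2CCOCC2)c1` changes that same place, with 3,5-dibromo-2-hydroxyphenyl in place of 5-chloro-2-hydroxyphenyl on a carbon with a double bond to nitrogen. The hydroxyphenyl group of compound 2 stays and only its halogens differ, so a smaller change is expected than an at least 6.0-fold lower number from compound 1 to compound 2 (0.78 log units; beyond the scatter), and in the same direction. The expected step is a 2.4-fold lower number from compound 2 to compound 3 (0.37 log units; beyond the scatter). For compound 3 the estimate is 7000 nM, with an expected range of 2000 nM to 22000 nM.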

Compound 3, half-maximal inhibitory concentration: 16000 nM
Compound 3: the middle estimate sits 2.3-fold (0.36 log units) below what was measured, within the range that was stated.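

On a carbon with a double bond to nitrogen, 3,5-dibromo-2-hydroxyphenyl in place of 5-chloro-2-hydroxyphenyl gives a 1.0-fold lower number from compound 2 to compound 3 (0.01 log units; within the scatter), so in this assay this exchange of halogens leaves the read-out unmoved. Against pyridin-2-yl the dibromo group gives an at least 6.2-fold lower number from compound 1 to compound 3 (0.79 log units; beyond the scatter), which shows that the advantage of the hydroxyphenyl compounds is not tied to the single chlorine of compound 2. The entry for compound 1 is a limit and not a number, so both steps from it have no measured size: the limit of > 100000 nM in this assay, at which 1 of the 3 values shown sits.

The compounds shown leave open whether the hydroxyl group carries this advantage, a question that a 2-methoxyphenyl group would address. They also leave open whether any halogen is needed, which a plain 2-hydroxyphenyl group would settle.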